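Dechlorination step in the benzoxazole piperazine series

The source may hold more compounds than are shown below. What is called first, only, known or untested is meant among the compounds shown, and "the series" means these compounds.

Compound 1 `CN1CCN(c2nc3cccc(Cl)c3o2)CC1` gives 5.5 in a functional assay on ileum (strain Hartley) for agonist activity at 5-hydroxytryptamine receptor 3A (Cavia porcellus); a lower number here means a less potent compound, a higher number a more potent compound, by a factor of ten per unit of this negative logarithm. Compound 2 `CN1CCN(c2nc3cc(Cl)cc(Cl)c3o2)CC1` gives 6.51 there, and compound 3 `CCc1cc(Cl)cc2nc(N3CCN(C)CC3)oc12` gives 6.82, the highest of the three. The measured step of a number 1.01 log units lower from compound 2 to compound 1 (beyond the scatter) arises from hydrogen in place of chloro on an aromatic carbon. The cores of compound 2 and compound 3 differ by ethyl in place of chloro on an aromatic carbon, and the step of a number 0.31 log units higher from compound 2 to compound 3 (beyond the scatter) is modest. Compound 4 `CCc1cccc2nc(N3CCN(C)CC3)oc12` is not yet measured; it differs from compound 3 by hydrogen in place of chloro on an aromatic carbon. This is the same kind of change as from compound 2 to compound 1, though the place is meta to an ethyl group rather than meta to a chloro group. Resting on the large loss seen in a number 1.01 log units lower from compound 2 to compound 1 (beyond the scatter), compound 4 is expected to fall by about a number 1.02 log units lower from compound 3 to compound 4 (beyond the scatter), giving an estimated 5.8 with a likely range from 5.3 to 6.4.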

Compound 4, negative logarithm of the half-maximal effective concentration: 5.48
The estimate for compound 4 lay 0.32 log units above the measured number; the range from low to high includes it.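

In this assay, hydrogen in place of chloro carries over between the two cores, with a number 1.34 log units lower from compound 3 to compound 4 (beyond the scatter) standing close to the earlier loss: the same change on two cores in this assay, a number 1.01 log units lower (beyond the scatter) from compound 2 to compound 1 and a number 1.34 log units lower (beyond the scatter) from compound 3 to compound 4, 0.33 log units apart, within the scatter of two such steps Ethyl in place of chloro gives a number 0.02 log units lower from compound 1 to compound 4 (within the scatter), and this step also does not separate from its counterpart on the other core: the same change on two cores in this assay, a number 0.31 log units higher (beyond the scatter) from compound 2 to compound 3 and a number 0.02 log units lower (within the scatter) from compound 1 to compound 4, 0.33 log units apart, within the scatter of two such steps This shows agreement only within one closed set of four compounds, so it does not show that either change would keep its size on a core carrying any other group.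

Going by these compounds, whether methoxy, fluoro or a longer chain in place of the chloro would give a similar step stays open. So does the effect of replacing the methyl group that all four compounds carry.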